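Tert-Butyl Enters Where Both Measured Values Are Limits

The compounds below may be only part of what the source reports. "The series", "measured", "known", "first", "only" and "open" are said of these compounds alone.

In an ADME assay on MT4 cells (Homo sapiens) for cytotoxicity, read by MTT assay, with a stated time of 3 days (on this read-out higher numbers stand for lower toxicity in this test and lower numbers for higher toxicity in this test), compound 1 (`CC(C)OC(=O)COC(=O)c1ccc([N+](=O)[O-])o1`) gives > 100000 nM as a limit of the test. Compound 2 (`O=C(COC(=O)c1ccc([N+](=O)[O-])o1)NCC1CCCO1`) gives > 100000 nM which is likewise a limit and not a number. Compound 2 thus has no exact position, and the evidence amounts to the limit of > 100000 nM in this assay, at which 2 of the 2 values shown sit, and nothing finer. Going by the values given here, the one measured step, a step that the two limits leave unreadable from compound 1 to compound 2, offers no size to carry forward. Compound 3 (`CC(C)(C)C(=O)COC(=O)c1ccc([N+](=O)[O-])o1`) differs from compound 2 on the same kind of site: tert-butyl in place of ((oxolan-2-yl)methyl)amino on a carbonyl carbon with tert-butyl in place of ((oxolan-2-yl)methyl)amino on a carbonyl carbon. With no readable step to draw on, no change beyond the scatter and no direction is expected in this assay here. The expected outcome is a number no higher from compound 2 to compound 3 (the limit leaves the size open) in this account. In this assay compound 3 is estimated at 100000 nM with an expected range from 30000 nM to 300000 nM and another limit is quite likely.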

Compound 3, half-maximal cytotoxic concentration: > 100000 nM
Compound 3 ended at the assay's limit (the forecaster's own chance of this, stated with the estimate: 65%); the middle value sits exactly at the limit.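

In this assay compound 3 gives > 100000 nM, which is a limit of the test. Going by these compounds alone, no step among compound 1, compound 2 and compound 3 can be read. The compounds shown leave open whether any change on the carbonyl carbon alters this read-out, with all values at one limit: the limit of > 100000 nM in this assay, at which 3 of the 3 values shown sit.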